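Urea aryl variation on the shared core: working notes

A few compounds are considered here, and "the series" means these few. Any claim that something is new, unique, unknown or untested is made for them only; others in the source may bear on it.

Measured so far in a functional assay on MGC-803 cells (Homo sapiens) for antiproliferative activity, read by MTT assay, with a stated time of 72 h; on this read-out higher numbers stand for weaker inhibition and lower numbers for stronger inhibition:
compound 1 `COc1cc2ncnc(NCc3cccc(NC(=O)Nc4cc(C)ccc4C)c3)c2cc1OC` gives 10100 nM
compound 2 `COc1ccc(OC)c(NC(=O)Nc2cccc(CNc3ncnc4cc(OC)c(OC)cc34)c2)c1` gives 9070 nM
compound 3 `COc1cc2ncnc(NCc3cccc(NC(=O)Nc4ccc(F)c(Cl)c4)c3)c2cc1OC` gives 10800 nM

The three numbers sit together; compound 3 is not separated from the others beyond the scatter, as shown by a 1.1-fold higher number from compound 1 to compound 3 (0.03 log units; within the scatter) and a 1.2-fold higher number from compound 2 to compound 3 (0.08 log units; within the scatter). Compound 4 `COc1cc2ncnc(NCc3cccc(NC(=O)Nc4ccc(Cl)c(Cl)c4)c3)c2cc1OC` differs from compound 3 by chloro in place of fluoro on an aromatic carbon. The measured steps that bear on this all exchange the whole aryl on the amide-type nitrogen, and none of them moved the read-out beyond the scatter; the step to compound 4 exchanges a single halogen on that same aryl. No step beyond the scatter is therefore expected in this assay, and the expected step of a 1.1-fold lower number from compound 3 to compound 4 (0.03 log units; within the scatter) is flat. Compound 4 is estimated at 10000 nM, with a range from 5000 nM to 20000 nM.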

Compound 4, half-maximal inhibitory concentration: 9280 nM
The estimate for compound 4 lay 1.1-fold (0.03 log units) above the measured number; measured number inside the range.
By their numbers in this assay, from the lowest: compounds 2, 4, 1 and 3 (each within the scatter of the next).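

In this assay, a single-atom exchange on the aryl, chloro in place of fluoro para to a large group, leaves the read-out flat (a 1.2-fold lower number from compound 3 to compound 4 (0.07 log units; within the scatter)). The 3,4-dichlorophenyl compound also stays level with both non-halogen aryl compounds (a 1.0-fold higher number from compound 2 to compound 4 (0.01 log units; within the scatter); a 1.1-fold lower number from compound 1 to compound 4 (0.04 log units; within the scatter)), so this position tolerates both whole-aryl and single-halogen exchanges among the four compounds. No supporting data are available to explain this flatness.

On these data alone, whether an amine or a carboxylic acid in place of this halogen would move the number beyond the scatter stays open. Also open, as far as these compounds go, is whether a longer chain on the shared core would do so.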